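A few compounds are considered here, and "the series" means these few. Any claim that something is new, unique, unknown or untested is made for them only; others in the source may bear on it.

Measured so far:
compound 1, `COc1ccccc1CNc1ncnc2c1ncn2[C@@H]1O[C@H](CO)[C@@H](O)[C@H]1O`: > 166000 nM in a functional assay on MCF cells (Homo sapiens) for antiproliferative activity, with a stated time of 72 h; a higher number here means a weaker inhibitor, a lower number a stronger inhibitor
compound 2, `COc1cc(CNc2ncnc3c2ncn3[C@@H]2O[C@H](CO)[C@@H](O)[C@H]2O)cc(OC)c1O`: > 166000 nM in this assay

Both entries are limits of the assay rather than numbers. For compound 1 the value > 166000 nM is such a limit. For compound 2 the value > 166000 nM is likewise a limit. Going by the values given here, compound 1 therefore stands nowhere within a measured range: the limit of > 166000 nM in this assay, at which 2 of the 2 values shown sit, so no step between measured compounds can be drawn, and the pair compound 1 and compound 2 shows only that neither reached a number.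

Compound 3, `Cc1cccc(CNc2ncnc3c2ncn3[C@@H]2O[C@H](CO)[C@@H](O)[C@H]2O)c1O`, is not yet measured. It differs from compound 1 in one place: 2-hydroxy-3-methylphenyl in place of 2-methoxyphenyl on a saturated chain carbon bound to a nitrogen on an aromatic ring. Among the compounds with values here, with no measured step to lean on, the size of the step in this assay from compound 1 to compound 3 cannot be read from the data, and an expectation of no step beyond the scatter is all the two limits support. Compound 3 is therefore expected to give 166000 nM, between 40000 nM and 600000 nM, most likely again as a limit. The expected step of a number no higher from compound 1 to compound 3 (the limit leaves the size open) is none beyond the scatter.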

Compound 3, half-maximal inhibitory concentration: 6900 nM
Estimate against measurement, compound 3: 24-fold (1.38 log units) above; measured number outside the range, below it.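

In this assay, going by these compounds alone, 2-hydroxy-3-methylphenyl in place of 2-methoxyphenyl on a saturated chain carbon bound to a nitrogen on an aromatic ring gives an at least 24-fold lower number from compound 1 to compound 3 (1.38 log units; beyond the scatter), and compound 3 is the first to give a number rather than a limit. The aryl group at this place can therefore decide whether the series reaches a measurable value at all, and here the change leaves the heavy-atom count as it was while the entering group carries a hydrogen-bond donor that the leaving group lacks. The true size of the step stays unknown, since compound 1 gives only a limit: the limit of > 166000 nM in this assay, at which 2 of the 3 values shown sit.

The change alters two things at once, so the compounds shown do not tell whether the gain belongs to the hydroxy group or to the methyl group, a question that a plain 2-hydroxyphenyl or 3-methylphenyl group at the same place would separate. Also open, going by these compounds, is whether the hydroxy group can give way to an amine or a carboxylic acid, or the methyl group to an ethyl group, with the number kept.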